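Piperidin-1-yl in place of propylamino on a carbonyl carbon

The compounds below may be only part of what the source reports. "The series", "measured", "known", "first", "only" and "open" are said of these compounds alone.

Compound 1 `CCCNC(=O)c1ccc(-n2cc(-c3cc(F)cc(F)c3)nn2)cc1O`: > 20000 nM
Compound 2 `CCCNC(=O)c1ccc(-n2cc(-c3cc(C(F)(F)F)cc(C(F)(F)F)c3)nn2)cc1O`: > 20000 nM

Both compounds were tested in a functional assay on RAW264.7 cells (Mus musculus) for inhibition, read by Griess assay, with a stated time of 20 h; a lower number here means a stronger inhibitor, a higher number a weaker inhibitor. In this assay compound 1 gives > 20000 nM, which is a limit of the assay and not a number. Compound 2 likewise gives > 20000 nM, also a limit and not a number. Going by the values given here, the standing of compound 2 is therefore given only by the limit of > 20000 nM in this assay, at which 2 of the 2 values shown sit, and no step between the two measured compounds can be read from these results.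

Compound 3 `O=C(c1ccc(-n2cc(-c3cc(C(F)(F)F)cc(C(F)(F)F)c3)nn2)cc1O)N1CCCCC1` keeps the core of compound 2 and changes only the amide: piperidin-1-yl in place of propylamino on a carbonyl carbon. In words, piperidin-1-yl stands in place of propylamino on a carbonyl carbon.

Neither measured compound provides a number to build on, so no step beyond the scatter is expected in this assay, and any change in direction cannot be predicted with confidence. A weak but measurable value remains possible. The estimated change is a number no higher from compound 2 to compound 3 (the limit leaves the size open). The expected value for compound 3 is 20000 nM, with an estimated range of 9000 nM to 40000 nM.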

Compound 3, half-maximal inhibitory concentration: > 20000 nM
Compound 3: a limit, no number; the forecaster's own chance of this, stated with the estimate: 60%; the middle value sits exactly at the limit.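

In this assay compound 3 gives > 20000 nM, which is a limit and not a number. Compound 2 also stands at a limit, so no step can be read between compound 2 and compound 3: the limit of > 20000 nM in this assay, at which 3 of the 3 values shown sit. The compounds shown leave open whether exchanging propylamino for piperidin-1-yl changes inhibition at all.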